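A few compounds are considered here, and "the series" means these few. Any claim that something is new, unique, unknown or untested is made for them only; others in the source may bear on it.

Measured compounds:
compound 1, `NC(=O)CC[C@H](NC(=O)CN(c1ncnc2c1ncn2C1CCCCO1)C1CC1)C(=O)OCc1ccccc1`, 39.4%;
compound 2, `C[C@H](NC(=O)CN(c1ncnc2c1ncn2C1CCCCO1)C1CC1)C(=O)OCc1ccccc1`, 53%;
compound 3, `NC(=O)CC[C@H](NC(=O)CN(c1nc(Cl)nc2[nH]cnc12)C1CC1)C(=O)O`, 38.4%.

In a functional assay on the whole organism (Tail, strain ICR) with Mus musculus as the target, in the tail flick test, with a stated time of 60 min, at a dose of 25 umol/kg by the oral route (on this read-out lower numbers stand for a weaker effect and higher numbers for a stronger effect at the one dose given), compound 1 gives 39.4%, and compound 2 gives 53%. The change between them is hydrogen in place of carbamoylmethyl on a saturated chain carbon, two bonds along the chain from an amide-type nitrogen and a carbonyl carbon, and it brought a number 13.6 percentage points higher from compound 1 to compound 2 (beyond the scatter). Compound 3 gives 38.4% in this assay; the difference between its core and the core of compound 1 is not broken down here. Compound 4, `C[C@H](NC(=O)CN(c1nc(Cl)nc2[nH]cnc12)C1CC1)C(=O)O`, has not been measured. It differs from compound 3 by hydrogen in place of carbamoylmethyl on a saturated chain carbon, two bonds along the chain from an amide-type nitrogen and a carbonyl carbon, the same change as between compound 1 and compound 2, at the same place. Resting on the step of a number 13.6 percentage points higher from compound 1 to compound 2 (beyond the scatter), the expected step is a number 11.6 percentage points higher from compound 3 to compound 4 (beyond the scatter), with wider uncertainty since the core of compound 3 differs from that of compound 1. Compound 4 is thus estimated at 50%, between 38% and 62%.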

Compound 4, a percentage reported as activity, at one dose (the size of the read-out at that dose, not a potency): 44.6%
Compound 4: the middle estimate sits 5.4 percentage points above what was measured, and the stated range covers the measured number.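

In this assay, hydrogen in place of carbamoylmethyl on the core of compound 3 gives a number 6.2 percentage points higher from compound 3 to compound 4 (within the scatter). Set beside the same change on the core of compound 1, the two steps cannot be told apart: the same change on two cores in this assay, a number 13.6 percentage points higher (beyond the scatter) from compound 1 to compound 2 and a number 6.2 percentage points higher (within the scatter) from compound 3 to compound 4, 7.4 percentage points apart, within the scatter of two such steps This shows that the change carries across these two cores without a detectable difference in step size, but it rests on one pair per core and does not show that the two steps are equal or that the second step is real.

The compounds shown leave open how other groups at this place, such as an amine, a carboxylic acid or a longer chain, would compare. As far as these compounds go, whether the change carries to any further core also remains open.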